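Lengthening the Amide Chain on the Shared Core

The source may report more compounds than this note shows. Statements on the series, on what has been measured and on what is new or still open speak of the compounds shown alone.

Compound 1 `C=CC1=C(C(=O)NCc2ccc(Cl)cc2)C(c2ccc(OC)cc2)OC1` gives in a functional assay on QGY7701 cells (Homo sapiens) for cytotoxicity, read by MTT assay, with a stated time of 24 h; a lower number here means a stronger inhibitor, a higher number a weaker inhibitor > 100000 nM, which is a limit of the assay and not a number.
Compound 2 `C=CC1=C(C(=O)NCc2ccccc2)C(c2ccc(Cl)c(Cl)c2)OC1` gives in this assay > 100000 nM, again a limit rather than a number.
Compound 3 `C=CC1=C(C(=O)NCCC)C(c2ccc(Cl)c(Cl)c2)OC1` gives in this assay 31300 nM.

Compound 3 thus holds the only number shown; the other two values sit at a limit (the limit of > 100000 nM in this assay, at which 2 of the 3 values shown sit). Within the data shown here, the single measured step, an at least 3.1-fold lower number from compound 2 to compound 3 (0.50 log units; beyond the scatter), concerns ethyl in place of phenyl on a saturated chain carbon bound to an amide-type nitrogen. Compound 4 `C=CC1=C(C(=O)NCCCCC)C(c2ccc(Cl)c(Cl)c2)OC1` differs from compound 3 by ethyl in place of hydrogen on a saturated chain carbon, three bonds along the chain from an amide-type nitrogen. Among the measured compounds shown here, no measured step tracks such a lengthening, so no change beyond the scatter is expected in this assay. Compound 4 is expected to give 25000 nM, between 8000 nM and 80000 nM. The expected step of a 1.3-fold lower number from compound 3 to compound 4 (0.10 log units; within the scatter) stays within the scatter.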

Compound 4, half-maximal inhibitory concentration: > 100000 nM
Compound 4: only a limit was reported; the forecaster's own chance of this, stated with the estimate: 20%; at least 4.0-fold (0.60 log units) between middle value and limit.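

The position proves sensitive in this assay: ethyl in place of hydrogen, three bonds along the chain from an amide-type nitrogen, gives an at least 3.1-fold higher number from compound 3 to compound 4 (0.50 log units; beyond the scatter). So the earlier gain on leaving the phenyl group does not carry over to the longer chain, and the propyl chain of compound 3 stands alone with a number. The other compounds stay at a limit, which is not a number: the limit of > 100000 nM in this assay, at which 3 of the 4 values shown sit.

The two limits leave the step between compound 2 and compound 4 unreadable. On these data alone, whether a butyl chain, or a propyl chain ending in an amine or a carboxylic acid, would give a lower number stays open.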